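Removing the nitrile from the biaryl of compound 1

The source may hold more compounds than are shown below. What is called first, only, known or untested is meant among the compounds shown, and "the series" means these compounds.

Two compounds of this series carry numbers in a functional assay on NCI-H460 cells (Homo sapiens) for inhibition, with a stated time of 72 h; a higher number here means a weaker inhibitor, a lower number a stronger inhibitor. Compound 1 `COc1ccc(S(=O)(=O)N2CCc3cccc(-c4ccc(C#N)cc4)c32)cc1` gives 29.5 nM and stands lowest of the two. Compound 2 `COc1ccc(S(=O)(=O)N2CCc3cccc(-c4ccc(F)nc4)c32)cc1` gives 135 nM. Among the measured compounds shown here, the single step between them, a 4.6-fold higher number from compound 1 to compound 2 (0.66 log units; beyond the scatter), came from 6-fluoropyridin-3-yl in place of 4-cyanophenyl on an aromatic carbon.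

Compound 3 `COc1ccc(S(=O)(=O)N2CCc3cccc(-c4ccccc4)c32)cc1` has not yet been measured. It differs from compound 1 in one place: hydrogen in place of cyano on an aromatic carbon. For the measured compounds named here, no measured step strips the cyano on its own; the step from compound 1 to compound 2 is the only one touching this aryl group, and it exchanged the whole 4-cyanophenyl at once, so it bears only loosely on compound 3. That step was beyond the scatter and toward a higher number, and it removed the cyano among other things, so for compound 3 a higher number than compound 1 is expected, probably beyond the scatter but of smaller size than a 4.6-fold higher number from compound 1 to compound 2 (0.66 log units; beyond the scatter). The expected step is a 3.1-fold higher number from compound 1 to compound 3 (0.48 log units; beyond the scatter). Compound 3 is therefore estimated at 90 nM, with a range from 30 nM to 300 nM.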

Compound 3, half-maximal inhibitory concentration: 213 nM
The estimate for compound 3 lay 2.4-fold (0.37 log units) below the measured number; the range from low to high includes it.
By their numbers in this assay, from the lowest: compound 1; then compounds 2 and 3 (each within the scatter of the next).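

Hydrogen in place of cyano on the aromatic carbon gives the first clean reading of the nitrile alone in this assay: it is a 7.2-fold higher number from compound 1 to compound 3 (0.86 log units; beyond the scatter) and is larger in size than the earlier change of the whole aryl group, a 4.6-fold higher number from compound 1 to compound 2 (0.66 log units; beyond the scatter). Phenyl and 6-fluoropyridin-3-yl are not separated at this position, with a 1.6-fold higher number from compound 2 to compound 3 (0.20 log units; within the scatter), so among the compounds shown only the 4-cyanophenyl of compound 1 stands apart, and the fluorine and ring nitrogen of compound 2 do not recover what the nitrile provides. No measurement available here bears on what lies behind the nitrile's contribution.

As far as these compounds go, it remains open whether the nitrile itself is needed or whether another group on the same aromatic carbon, such as a primary carboxamide, a trifluoromethyl, a methoxy or an aminomethyl, would serve equally well. Also unresolved is whether a nitrile on the pyridine ring of compound 2, in place of its fluorine, would match the number of compound 1.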